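A few compounds are considered here, and "the series" means these few. Any claim that something is new, unique, unknown or untested is made for them only; others in the source may bear on it.

The measured compounds:
Compound 1, `O=C(/C=C\c1ccccc1)N1N=C(c2ccncc2)OC1c1c[nH]c2ccccc12`, in an ADME assay on PANC-1 cells (Homo sapiens) for cytotoxicity, read by MTT assay, with a stated time of 48 h (a lower number here means a stronger inhibitor of growth, a higher number a weaker inhibitor of growth), gives > 30 ug/mL, which is a limit of the assay and not a number.
Compound 2, `O=C(/C=C\c1cccc(O)c1)N1N=C(c2ccncc2)OC1c1c[nH]c2ccccc12`, in this assay gives > 30 ug/mL, again only a limit.
Compound 3, `Cc1ccc(/C=C\C(=O)N2N=C(c3ccncc3)OC2c2c[nH]c3ccccc23)cc1`, in this assay gives > 30 ug/mL, likewise a limit.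

Among the compounds with values here, compound 3 therefore stands at the limit of > 30 ug/mL in this assay, at which 3 of the 3 values shown sit; no measured compound in this set has given a true number. The steps among the measured compounds, a step that the two limits leave unreadable from compound 1 to compound 2, a step that the two limits leave unreadable from compound 1 to compound 3 and a step that the two limits leave unreadable from compound 2 to compound 3, are all of unreadable size, their two ends both resting on the limit.

Compound 4, `O=C(/C=C/c1c(Cl)cccc1Cl)N1N=C(c2ccncc2)OC1c1c[nH]c2ccccc12`, differs from compound 3 by 2-(2,6-dichlorophenyl)ethenyl in place of 2-(4-methylphenyl)ethenyl on a carbonyl carbon. Within the data shown here, none of the measured steps speaks readably to this change; what they do show is that changes on the aryl ring of the ethenyl group, hydroxy and methyl, left every value at the limit. The expectation for compound 4 in this assay is thus no readable step, most probably another limit, with a weakly active number the less likely outcome. Compound 4 is estimated at 40 ug/mL, in the range from 15 ug/mL to 120 ug/mL. The expected step is a step that the limit leaves unreadable from compound 3 to compound 4.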

Compound 4, concentration for 50% growth inhibition: > 30 ug/mL
Compound 4 ended at the assay's limit; the forecaster's own chance of this, stated with the estimate: 75%; the middle value is on the limit's open side.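

Compound 4, like compound 1, compound 2 and compound 3, gives a limit and not a number, so none of the steps to compound 4 can be read: the limit of > 30 ug/mL in this assay, at which 4 of the 4 values shown sit.

The compounds shown leave open what true value any of these four compounds has in this assay, and whether any change to the group on the carbonyl carbon would give a readable number there.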